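The source may hold more compounds than are shown below. What is called first, only, known or untested is meant among the compounds shown, and "the series" means these compounds.

Measured so far:
- compound 1 `O=S(=O)(c1ccccc1)c1nc2ccccc2nc1N1CCC(O)CC1`, in a functional assay on PC-3 cells (Homo sapiens) for cytotoxicity, read by MTT assay, with a stated time of 72 h (on this read-out lower numbers stand for stronger inhibition and higher numbers for weaker inhibition), compound 1 gives 4980 nM
- compound 2 `Cc1ccc(S(=O)(=O)c2nc3ccccc3nc2N2CCC(O)CC2)cc1`, in this assay compound 2 gives 9520 nM

Compound 2 has the highest of the two numbers; its nearest neighbour is compound 1, and the step of a 1.9-fold higher number from compound 1 to compound 2 (0.28 log units; within the scatter) lies within the scatter, so no order between the two can be read.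

The next compound, compound 3 `O=S(=O)(c1ccc(F)cc1)c1nc2ccccc2nc1N1CCC(O)CC1`, differs from compound 2 in one place: fluoro in place of methyl on an aromatic carbon.

Among the compounds with values here, only one measured step bears on this position, a 1.9-fold higher number from compound 1 to compound 2 (0.28 log units; within the scatter), which exchanged hydrogen for methyl on that same aromatic carbon and stayed within the scatter. A second small substituent at the same place, fluoro, gives no ground to expect a step beyond the scatter in this assay in either direction; the expected step is a 1.5-fold lower number from compound 2 to compound 3 (0.17 log units; within the scatter).

Compound 3 is therefore estimated at 6500 nM, with a range from 2500 nM to 17000 nM.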

Compound 3, half-maximal inhibitory concentration: 2010 nM
Compound 3: the middle estimate sits 3.2-fold (0.51 log units) above what was measured; the measured number lies below the stated range.
By their numbers in this assay, from the lowest: compound 3; then compounds 1 and 2 (each within the scatter of the next).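

In this assay this aromatic carbon proves sensitive to the choice of substituent, which the hydrogen-to-methyl exchange alone did not show: fluoro gives a 4.7-fold lower number from compound 2 to compound 3 (0.68 log units; beyond the scatter) and also a 2.5-fold lower number from compound 1 to compound 3 (0.39 log units; beyond the scatter), both modest but beyond the scatter. Compound 3 therefore separates from both earlier compounds, while compound 1 and compound 2 still cannot be ordered against each other. The material at hand offers no measurement that explains this separation.

As far as these compounds go, whether the lower number is particular to fluoro or extends to chloro, bromo, methoxy or a nitrile on the same carbon remains open. Also open, from the compounds shown here alone, is whether the fluoro gain would persist if the hydroxyl group on the shared core gave way to an amine or a carboxylic acid.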